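The compounds below may be only part of what the source reports. "The series", "measured", "known", "first", "only" and "open" are said of these compounds alone.

Measured so far in a functional assay on cells (Homo sapiens) for cytotoxicity, read by MTT assay, with a stated time of 24 h; a higher number here means a weaker inhibitor, a lower number a stronger inhibitor:

- compound 1 `CCCCCCCCCCCCCCNC(=O)[C@H](CO)/N=C/c1cccc(OC)c1` gives 31300 nM
- compound 2 `CCCCCCCCCCCCCCNC(=O)[C@H](CO)/N=C/c1cccc([N+](=O)[O-])c1` gives 104000 nM
- compound 3 `CCCCCCCCCCCCCCNC(=O)[C@H](CO)NCc1ccccc1OC` gives 100000 nM

Compound 3 and compound 2 lie within the usual scatter of each other, so neither can be ranked above the other. The remaining gap is larger, and it reads a 3.2-fold higher number from compound 1 to compound 3 (0.50 log units; beyond the scatter).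

The next compound is compound 4 `CCCCCCCCCCCCCCNC(=O)[C@H](CO)NCc1ccccc1Cl`. It differs from compound 3 in one place, with chloro in place of methoxy on an aromatic carbon, ortho to a large group: chloro in place of methoxy on an aromatic carbon.

Among the compounds with values here, no measured pair makes this exact swap, and no chloro compound has a value yet. The closest guide also replaces methoxy on an aromatic carbon, though with nitro and on a different version of the core, and it is modest: a 3.3-fold higher number from compound 1 to compound 2 (0.52 log units; beyond the scatter). One step of another kind gives no firm direction, so no step beyond the scatter is expected here.

The expected change is a 1.4-fold lower number from compound 3 to compound 4 (0.15 log units; within the scatter). The estimate for compound 4 is 70000 nM, with an expected range from 25000 nM to 200000 nM.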

Compound 4, half-maximal inhibitory concentration: 43700 nM
Beside the measured number, compound 4's estimate is 1.6-fold (0.20 log units) above it, and the stated range covers the measured number.
By their numbers in this assay, from the lowest: compounds 1 and 4 (each within the scatter of the next); then compounds 3 and 2 (each within the scatter of the next).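

In this assay, within the data shown here, the change from 2-methoxybenzyl to 2-chlorobenzyl gives a 2.3-fold lower number from compound 3 to compound 4 (0.36 log units; beyond the scatter) and so shows that this ring carbon, ortho to a large group, responds to the group it carries, with chloro measured there for the first time. The second step reads a 1.4-fold higher number from compound 1 to compound 4 (0.14 log units; within the scatter) and stays within the scatter, so these numbers do not separate compound 4 from compound 1 even though the two differ in the group attached to the shared core. Nothing measured here accounts for the difference between the chloro and methoxy compounds.

The compounds shown leave open how fluoro or methyl would compare with chloro at this same ring carbon, and whether chloro on another ring carbon would give a similar result. They also leave open whether the same swap from methoxy to chloro would give a similar step on the version of the core found in compound 1.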